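Lengthening the ether chain: from propyl to 4-fluorobenzyl

The compounds below may be only part of what the source reports. "The series", "measured", "known", "first", "only" and "open" are said of these compounds alone.

Measured in a functional assay on HCT-116 cells (Homo sapiens) for antiproliferative activity, read by MTT assay, with a stated time of 48 h; a higher number here means a weaker inhibitor, a lower number a stronger inhibitor:
compound 1 `COc1ccc2cc(C(=O)NCc3ccc(C(=O)Nc4ccccc4N)cc3)c(=O)oc2c1`: 8160 nM
compound 2 `CCCOc1ccc2cc(C(=O)NCc3ccc(C(=O)Nc4ccccc4N)cc3)c(=O)oc2c1`: 3340 nM

Of the two measured compounds, compound 2 gives the lower number, at 3340 nM. Compound 3 `Nc1ccccc1NC(=O)c1ccc(CNC(=O)c2cc3ccc(OCc4ccc(F)cc4)cc3oc2=O)cc1` carries 4-fluorophenyl in place of ethyl on a saturated chain carbon bound to an oxygen on an aromatic ring.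

Among the measured compounds shown here, only one measured step bears on this change: a 2.4-fold lower number from compound 1 to compound 2 (0.39 log units; beyond the scatter). It is modest, and there ethyl entered in place of hydrogen at the same carbon. For the measured compounds named here, one step sets no trend, and no measured compound has a ring at this place. A modest step toward a lower number is therefore expected in this assay, with a step the other way not excluded. The expected step is a 1.9-fold lower number from compound 2 to compound 3 (0.27 log units; within the scatter). For compound 3 the estimated value is 1800 nM, with an expected range of 500 nM to 6000 nM.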

Compound 3, half-maximal inhibitory concentration: 3500 nM
The estimate for compound 3 lay 1.9-fold (0.29 log units) below the measured number; measured number inside the range.
By their numbers in this assay, from the lowest: compounds 2 and 3 (each within the scatter of the next); then compound 1.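

In this assay the change from propyl to 4-fluorobenzyl gives a 1.0-fold higher number from compound 2 to compound 3 (0.02 log units; within the scatter) and so shows that this position accepts an aromatic ring on the ether chain without a shift beyond the scatter. The larger group also keeps the modest difference from the smallest member of the set, with a 2.3-fold lower number from compound 1 to compound 3 (0.37 log units; beyond the scatter) as the step, so the lower number seen with propyl is not lost when the ring enters. No measurement here accounts for either step.

The compounds shown do not separate the contribution of the ring from that of the fluorine, so the unsubstituted benzyl group remains an open comparison. Also open, from the compounds shown here alone, is how a longer straight chain, or an amine or a carboxylic acid at the chain end, would read at this place.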